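The source may hold more compounds than are shown below. What is called first, only, known or untested is meant among the compounds shown, and "the series" means these compounds.

Of the compounds shown here, three have been tested in an assay on Myocardium (Cavia porcellus) for displacement of a labelled ligand from Voltage-dependent L-type calcium channel subunit alpha-1C (Homo sapiens); on this read-out higher numbers stand for weaker binding and lower numbers for tighter binding. Compound 1 `COC(=O)C1=C(C)N=C(SC)NC1c1cccc([N+](=O)[O-])c1SC` gives 30 nM in this assay. For compound 2 `CSC1=NC(c2cc([N+](=O)[O-])ccc2SC)C2=C(O)OCC2=N1` this assay reports > 50000 nM, which is a limit of the measurement and not a number. Compound 3 `CSC1=NC2/C(=C(/O)OCCCCCSc3ccccc32)C(C)=N1` gives 18 nM in this assay, the lowest of the two numbers reported; the nearest is compound 1, and that gap lies within the usual scatter, so the two cannot be told apart. Compound 4 `CSC1=NC2/C(=C(/O)OCCCCCSc3c2cccc3[N+](=O)[O-])C(C)=N1` has not yet been measured. It differs from compound 3 by a single change, (nitro in place of hydrogen on an aromatic carbon), nitro in place of hydrogen on an aromatic carbon. Going by the values given here, no pair of measured compounds differs by exactly this change, so no measured step shows its effect; compound 1 also carries a nitro group, but on a different core, and its value cannot be read as a step. The expected step here is a 1.1-fold higher number from compound 3 to compound 4 (0.05 log units; within the scatter), small and not clearly in either direction. Compound 4 is therefore estimated at 20 nM, within a range from 6 nM to 80 nM.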

Compound 4, dissociation constant: 5 nM
Compound 4: middle estimate off by 4.0-fold (0.60 log units), on the high side; the whole stated range lies above it.
By their numbers in this assay, from the lowest: compound 4; then compounds 3 and 1 (each within the scatter of the next). At a limit, above all of these: compound 2.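

In this assay, going by these compounds alone, this is the first measured view of this change on this core: nitro in place of hydrogen on an aromatic carbon, ortho to a fused ring and meta to a fused ring, gives tighter binding (a 3.6-fold lower number from compound 3 to compound 4 (0.56 log units; beyond the scatter)). The step is modest but lies beyond the usual scatter, so this position takes a group of three heavy atoms with some gain in binding and no loss. Nothing in the data shown explains why the number falls.

From the compounds shown here alone, whether the gain belongs to nitro in particular stays open, and an amine or a carboxylic acid at this same position could give a quite different number. The compounds shown also leave open whether nitro on another carbon of this ring would give a similar step.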